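Notes on a sulfamate series: the aryl amine substituent

The compounds below may be only part of what the source reports. "The series", "measured", "known", "first", "only" and "open" are said of these compounds alone.

Compound 2, `CCN(Cc1cccnc1)c1ccc(C(=O)N2CCc3ccc(OS(N)(=O)=O)cc3C2)cc1`, gives 1.93 in a physicochemical assay for lipophilicity; on this read-out higher numbers stand for higher lipophilicity and lower numbers for lower lipophilicity. It stands level with compound 1, `CN(C)CCN(CCN(C)C)c1ccc(C(=O)N2CCc3ccc(OS(N)(=O)=O)cc3C2)cc1`, which gives 1.93 in this assay. Among the measured compounds shown here, the one measured step in the set, no change at the digits printed from compound 1 to compound 2 (within the scatter), is the exchange of bis(2-(dimethylamino)ethyl)amino for ethyl((pyridin-3-yl)methyl)amino on an aromatic carbon, and it left the read-out where it was.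

Compound 3, `NS(=O)(=O)Oc1ccc2c(c1)CN(C(=O)c1ccc(N3CCCCC3)cc1)CC2`, is not yet measured in this assay. It differs from compound 2 as follows: piperidin-1-yl in place of ethyl((pyridin-3-yl)methyl)amino on an aromatic carbon. The place is the same aromatic carbon, para to a large group, that was changed in the measured step, so that step bears on the question directly. There a substituent of comparable size was swapped without a shift beyond the scatter. For the measured compounds named here, the present change removes a six-membered aromatic ring with one hetero atom and one of two hydrogen-bond acceptors and brings in a smaller, saturated six-membered ring; on the one precedent the step is expected to be small, with some lean toward a slightly higher number, a number 0.27 log units higher from compound 2 to compound 3 (within the scatter).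

For compound 3 the estimate in this assay is 2.2, with a range from 1.7 to 2.7.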

Compound 3, partition coefficient: 1.93
Estimate against measurement, compound 3: 0.27 log units above, and the stated range covers the measured number.
By their numbers in this assay, from the lowest: compounds 1, 2 and 3 (each within the scatter of the next).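

In this assay, the change at this aromatic carbon from ethyl((pyridin-3-yl)methyl)amino to piperidin-1-yl gives no change at the digits printed from compound 2 to compound 3 (within the scatter), although a group of 10 heavy atoms with a six-membered aromatic ring gives way to one of 6 heavy atoms with a six-membered non-aromatic ring. The replacement of bis(2-(dimethylamino)ethyl)amino by piperidin-1-yl at the same carbon likewise gives no change at the digits printed from compound 1 to compound 3 (within the scatter), so the three substituents now shown there, one of them a simple cyclic amine, cannot be told apart on this read-out, and no compound shown goes against that. No evidence in hand says why the read-out stays the same across these exchanges.

The compounds shown leave open whether this carbon would stay as flat in this assay with a carboxylic acid, a primary amine or a long alkyl chain in place of these tertiary amines. Among the compounds shown here, they also leave open whether a change elsewhere on the shared core would move the number, since every step so far lies at this one aromatic carbon.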